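The source may hold more compounds than are shown below. What is called first, only, known or untested is meant among the compounds shown, and "the series" means these compounds.

Measured compounds:
Compound 1 `Cc1ccccc1C#Cc1ccc2c(n1)CCN(C(C)C)C2=O` gives 810 nM in a functional assay on HEK293 cells for negative allosteric modulation of metabotropic glutamate receptor 5 (Homo sapiens), read by FLIPR and calcium flux; on this read-out higher numbers stand for weaker inhibition and lower numbers for stronger inhibition.
Compound 2 `CC(C)N1CCc2nc(C#Cc3cccc(Cl)c3)ccc2C1=O` gives 5.7 nM in this assay.
Compound 3 `CC(C)N1CCc2nc(C#Cc3ccccn3)ccc2C1=O` gives 27 nM in this assay.

Among these three numbers compound 3 stands second highest: it is a 4.7-fold higher number from compound 2 to compound 3 (0.68 log units; beyond the scatter), and a 30-fold lower number from compound 1 to compound 3 (1.48 log units; beyond the scatter). The shared core stays the same throughout; only the ring attached to the triple-bonded carbon changes. Compound 4 `CC(C)N1CCc2nc(C#Cc3cccs3)ccc2C1=O` carries thiophen-2-yl in place of pyridin-2-yl on a triple-bonded carbon. Among the compounds with values here, no measured step swaps in a thiophen-2-yl, so the only guidance comes from the two steps that replace the ring at this same position, which gave a 140-fold lower number from compound 1 to compound 2 (2.15 log units; beyond the scatter) and a 30-fold lower number from compound 1 to compound 3 (1.48 log units; beyond the scatter): exchanges here can shift the number strongly in either direction. Within the data shown here, a five-membered ring with one hetero atom has no measured precedent here, so the step in this assay is expected to be small, probably a somewhat lower number than compound 3, though a step within the scatter is equally plausible. Compound 4 is therefore estimated at 15 nM, with a range from 4 nM to 60 nM, meaning an expected step of a 1.8-fold lower number from compound 3 to compound 4 (0.26 log units; within the scatter).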

Compound 4, half-maximal inhibitory concentration: 45 nM
Estimate against measurement, compound 4: 3.0-fold (0.48 log units) below, and the stated range covers the measured number.
By their numbers in this assay, from the lowest: compound 2; then compounds 3 and 4 (each within the scatter of the next); then compound 1.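

In this assay, a five-membered thiophen-2-yl can stand on the triple-bonded carbon in place of the six-membered pyridin-2-yl with a 1.7-fold higher number from compound 3 to compound 4 (0.22 log units; within the scatter), so this exchange of ring size and hetero atom together leaves the number within the usual scatter. Against the other two rings, the change is a 7.9-fold higher number from compound 2 to compound 4 (0.90 log units; beyond the scatter) and an 18-fold lower number from compound 1 to compound 4 (1.26 log units; beyond the scatter), which places thiophen-2-yl with pyridin-2-yl, clearly apart from both 3-chlorophenyl and 2-methylphenyl. Nothing available gives a reason for any of these steps.

Still open, going by these compounds, is where a plain phenyl, a furan-2-yl or a thiazol-2-yl would fall at this position. Also open, on these data alone, is whether a chlorine on the thiophen-2-yl would bring the number closer to that of compound 2.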